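This account rests on a few compounds, and the source may have more. Where it says the series, first, only, none or still open, it means among the compounds named here.

Four compounds share one core: compound 1 `CCCC(=O)N1CCC(N2CCN(C(=O)c3c(NC(=O)NCC)sc4ccccc34)CC2)CC1`, compound 2 `CCNC(=O)Nc1sc2ccccc2c1C(=O)N1CCN(C2CCN(C(=O)C3CCCCC3)CC2)CC1`, compound 3 `CCNC(=O)Nc1sc2ccccc2c1C(=O)N1CCN(C2CCN(C(=O)OC3CCCC3)CC2)CC1` and compound 4 `CCNC(=O)Nc1sc2ccccc2c1C(=O)N1CCN(C2CCN(C(=O)OC3CCCCC3)CC2)CC1`. In a functional assay on HepG2 cells (Homo sapiens) for inhibition, read by scintillation counting, with a stated time of 2 h (a lower number here means a stronger inhibitor, a higher number a weaker inhibitor), compound 1 has "not determined" (no result reported), compound 2 gives 146 nM and compound 3 gives 512 nM. Compound 3 thus holds the higher of the two numbers and is the weaker inhibitor of the pair. Compound 4, still unmeasured, differs from it by cyclohexyl in place of cyclopentyl on an oxygen next to a carbonyl group, with cyclohexyl in place of cyclopentyl on an oxygen next to a carbonyl group. Going by the values given here, the one measured step that bears on this is a 3.5-fold higher number from compound 2 to compound 3 (0.54 log units; beyond the scatter). Among the compounds with values here, that step changed the ring and brought in the oxygen together, so no measured pair isolates ring size. Only a small move toward a lower number in this assay is expected, a 1.6-fold lower number from compound 3 to compound 4 (0.20 log units; within the scatter). Compound 4 is estimated at 320 nM, with an expected range of 130 nM to 750 nM.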

Compound 4, half-maximal inhibitory concentration: 635 nM
The estimate for compound 4 lay 2.0-fold (0.30 log units) below the measured number, and the stated range covers the measured number.
By their numbers in this assay, from the lowest: compound 2; then compounds 3 and 4 (each within the scatter of the next).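

In this assay ring size now has a measured pair of its own: a 1.2-fold higher number from compound 3 to compound 4 (0.09 log units; within the scatter) for cyclohexyl in place of cyclopentyl on an oxygen next to a carbonyl group. With the cyclohexyl ring held constant, the oxygen also has its own pair, and a 4.3-fold higher number from compound 2 to compound 4 (0.64 log units; beyond the scatter) shows that this change, unlike the change in ring size, lies beyond the scatter. No measurement shown gives a reason for either step. From the compounds shown here alone, whether a methyl group, a longer open chain or a ring carrying an amine on this oxygen would give a different number remains open.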